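Swapping the Pyrimidine Ring for a Dione on Compound 2

The compounds below may be only part of what the source reports. "The series", "measured", "known", "first", "only" and "open" are said of these compounds alone.

Compounds measured so far:
- Compound 1, `Nc1ccccc1-c1cnc(C(=O)CCCCCCc2ccccc2)o1`: 750 nM
- Compound 2, `O=C(CCCCCCc1ccccc1)c1ncc(-c2ncccn2)o1`: 5.3 nM

In an assay (Rattus norvegicus) for inhibition of Fatty-acid amide hydrolase 1 (Homo sapiens) (on this read-out higher numbers stand for weaker inhibition and lower numbers for stronger inhibition), compound 2 gives the lowest of the two numbers, and its nearest neighbour is compound 1, which sits a 140-fold lower number from compound 1 to compound 2 (2.15 log units; beyond the scatter) away. Going by the values given here, that single step, the replacement of 2-aminophenyl by pyrimidin-2-yl, is the only comparison available.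

Compound 3, `O=C(CCCCCCc1ccccc1)c1ncc(-c2cc(=O)[nH]c(=O)[nH]2)o1`, has not yet been tested. It differs from compound 2 as follows: a group of 8 heavy atoms (4 carbon, 2 nitrogen, 2 oxygen; one six-membered aromatic ring with 2 hetero atoms) in place of a group of 6 heavy atoms (4 carbon, 2 nitrogen; one six-membered aromatic ring with 2 hetero atoms), on an aromatic carbon.

Among the compounds with values here, no measured step touches this exact change, so the one known step only sets the scale of what a swap at this position can do. That step was large. Within the data shown here, the group that enters brings two hydrogen-bond donors and two double bonds outside the aromatic ring, which the pyrimidin-2-yl of compound 2 lacks; compound 1, the only other example with a donor at this position, gave the higher number. The expected direction in this assay is therefore toward a higher number, and the expected step from compound 2 to compound 3 is an 11-fold higher number from compound 2 to compound 3 (1.05 log units; beyond the scatter), with a wide range. Compound 3 is estimated at 60 nM, between 10 nM and 400 nM.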

Compound 3, inhibition constant: 12 nM
Estimate against measurement, compound 3: 5.0-fold (0.70 log units) above; measured number inside the range.
By their numbers in this assay, from the lowest: compound 2; then compound 3; then compound 1.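

In this assay, the larger ring with its two carbonyls and its hydrogen-bond donors gives only a 2.3-fold higher number from compound 2 to compound 3 (0.35 log units; beyond the scatter), so this position of the shared core tolerates a group that differs considerably from pyrimidin-2-yl. Carrying hydrogen-bond donors at this position is therefore not enough on its own to produce a number as high as that of compound 1, since the entering group has them and still gives a 63-fold lower number from compound 1 to compound 3 (1.80 log units; beyond the scatter). What separates the two donor-bearing groups cannot be settled here, as no independent measurement bears on the result.

The compounds shown leave open how a plain phenyl ring or a carboxylic acid on this same aromatic carbon would read, and so whether the ring nitrogens shared by compound 2 and compound 3 are what sets them apart from compound 1. On these data alone, the chain ending in phenyl is also the same in all three compounds, so it remains unknown whether the same order would hold with a shorter chain.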